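The source may hold more compounds than are shown below. What is called first, only, known or untested is meant among the compounds shown, and "the series" means these compounds.

Compound 1 `Cc1cc(NC(=O)Cn2nnc(-c3ccccc3)n2)n(C2CCC(F)(F)CC2)n1` carries a 4,4-difluorocyclohexyl group on an aromatic nitrogen of its shared core. Going by the values given here, in an assay on HEK293 cells for activation of Kir3.1/Kir3.2 (Homo sapiens), read by thallium flux (a higher number here means that more compound is needed for the effect, a lower number that less compound is needed), compound 1 gives 84 nM, the lowest of the two numbers measured so far. Among the compounds with values here, the only other measured compound, compound 2 `CC1CC1c1cc(NC(=O)Cn2nnc(-c3ccccc3)n2)n(C2CCCCC2)n1`, gives 843 nM in this assay, a gap from compound 1 that lies beyond the usual scatter. Compound 2 differs from compound 1 in more than one place, so no single structural change can be read off from that pair.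

Compound 3 `Cc1cc(NC(=O)Cn2nnc(-c3ccccc3)n2)n(Cc2ccccc2)n1` has not yet been measured. It differs from compound 1 in one place: benzyl in place of 4,4-difluorocyclohexyl on an aromatic nitrogen. Within the data shown here, nothing among the measured compounds tests this change on its own, so the expectation rests only on the size of the variation seen so far. A modest rise in this assay, perhaps just beyond the scatter, is expected, and the estimated step is a 3.0-fold higher number from compound 1 to compound 3 (0.47 log units; beyond the scatter). Compound 3 is therefore expected to give about 250 nM in this assay, most likely somewhere between 80 nM and 800 nM.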

Compound 3, half-maximal effective concentration: 495 nM
The estimate for compound 3 lay 2.0-fold (0.30 log units) below the measured number; the measured number falls inside the stated range.
By their numbers in this assay, from the lowest: compound 1; then compounds 3 and 2 (each within the scatter of the next).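

Going by these compounds alone, exchanging the 4,4-difluorocyclohexyl group for benzyl gives a 5.9-fold higher number from compound 1 to compound 3 (0.77 log units; beyond the scatter) in this assay and provides the first reading of this position with the rest of the molecule held constant. The position is therefore sensitive to the group it carries, even though both groups contain one six-membered ring, neither has a hydrogen-bond donor or acceptor, and neither has a net charge. Nothing measured here explains what lies behind this step.

The change also alters several features at once: the ring becomes aromatic, the two fluorine atoms disappear, and a single carbon now links the ring to the core, so this pair cannot show which feature accounts for the step. Plain cyclohexyl or phenyl on the core of compound 1 would help separate these features, while a piperidine ring, which carries an amine, or a longer carbon chain would show how far this position tolerates groups of a different kind.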